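The source may report more compounds than this note shows. Statements on the series, on what has been measured and on what is new or still open speak of the compounds shown alone.

Measured in a physicochemical assay for lipophilicity, read by mass spectrometry; a lower number here means a more polar compound, a higher number a more lipophilic compound:
compound 1, `COc1ccc(NC(=O)C2Cc3cc(OC)c(OC)cc3C2=O)cc1`: 2.08
compound 2, `CCOc1ccc(NC(=O)C2Cc3cc(OC)c(OC)cc3C2=O)cc1`: 2.42
compound 3, `COc1ccccc1NC(=O)C1Cc2cc(OC)c(OC)cc2C1=O`: 2.08

Compound 1 and compound 2 differ by methyl in place of hydrogen on a saturated chain carbon bound to an oxygen on an aromatic ring; in this assay this change gave a number 0.34 log units higher from compound 1 to compound 2 (beyond the scatter). Compound 1 and compound 3 are built from the same atoms joined differently; the two cores differ by 2-methoxyphenyl in place of 4-methoxyphenyl on an amide-type nitrogen, and in this assay that gave no change at the digits printed from compound 1 to compound 3 (within the scatter). Compound 3 thus stands level with compound 1 at the digits recorded, and both lie furthest from compound 2.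

Compound 4, `CCOc1ccccc1NC(=O)C1Cc2cc(OC)c(OC)cc2C1=O`, has not yet been measured in this assay. It differs from compound 3 by methyl in place of hydrogen on a saturated chain carbon bound to an oxygen on an aromatic ring. The place is the same word for word as in the change from compound 1 to compound 2, so this is the same change, made here on the core of compound 3. Among the measured compounds shown here, only one measured instance of it exists, so the expectation rests on a single step.

Compound 4 is expected to sit around 2.42, because compound 3 gives 2.08 and the same change gave a number 0.34 log units higher from compound 1 to compound 2 (beyond the scatter). For compound 4 the expected range runs from 2.15 to 2.7, allowing for the scatter of such measurements. The step this estimate means is a number 0.34 log units higher from compound 3 to compound 4 (beyond the scatter). With two instances only, no wider pattern is claimed.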

Compound 4, partition coefficient: 2.42
Beside the measured number, compound 4's estimate shows no gap at the digits printed, and the stated range covers the measured number.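

In this assay the change from methoxy to ethoxy gave a number 0.34 log units higher from compound 3 to compound 4 (beyond the scatter) on the core of compound 3 and a number 0.34 log units higher from compound 1 to compound 2 (beyond the scatter) on the core of compound 1, so the step carried over between these two cores with the same printed size. This shows agreement in only two instances, on cores that differ solely by 2-methoxyphenyl in place of 4-methoxyphenyl on an amide-type nitrogen; it sets no rule for the series and says nothing about a core that differs in any other place. Nothing shown here accounts for the size of the step or for its agreement on the two cores.

The compounds shown carry only methoxy and ethoxy at this place, so it remains open whether a longer chain such as propoxy, or a chain ending in an amine or a carboxylic acid, would extend the same step or break from it. Also open, on these data alone, is whether the step from methyl to ethyl at this place would hold on cores with other groups on the amide-type nitrogen, such as an unsubstituted phenyl or a pyridine.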